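Dimethylbenzyl isomers: from compound 2 to compound 3

This account rests on a few compounds, and the source may have more. Where it says the series, first, only, none or still open, it means among the compounds named here.

Measured in a functional assay on Jurkat cells (Homo sapiens); a lower number here means a stronger inhibitor, a higher number a weaker inhibitor:
- compound 1 `C[C@H](NC(=O)C(=O)NCc1cccc(F)c1)C(=O)N[C@@H](CC(=O)O)C(=O)COc1c(F)c(F)cc(F)c1F`: 106 nM
- compound 2 `Cc1ccc(CNC(=O)C(=O)N[C@@H](C)C(=O)N[C@@H](CC(=O)O)C(=O)COc2c(F)c(F)cc(F)c2F)c(C)c1`: > 10000 nM

Compound 2 gives > 10000 nM, which is a limit of the assay and not a number.

Compound 3 `Cc1ccc(CNC(=O)C(=O)N[C@@H](C)C(=O)N[C@@H](CC(=O)O)C(=O)COc2c(F)c(F)cc(F)c2F)cc1C` keeps the rest of compound 2 and differs in one place: 3,4-dimethylphenyl in place of 2,4-dimethylphenyl on a saturated chain carbon bound to an amide-type nitrogen. Here 3,4-dimethylphenyl stands in place of 2,4-dimethylphenyl on a saturated chain carbon bound to an amide-type nitrogen.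

Going by the values given here, only one measured step bears on this place: an at least 94-fold higher number from compound 1 to compound 2 (1.97 log units; beyond the scatter). That step is large and beyond the scatter, so this group clearly matters in this assay. Among the compounds with values here, no measured compound yet carries 3,4-dimethylphenyl. Compound 1, at 106 nM, carries 3-fluorophenyl, whose name shares the 3 with the entering group, so a partial return towards compound 1 is expected rather than a full one. The expected change is an at least 8.3-fold lower number from compound 2 to compound 3 (0.92 log units; beyond the scatter), towards a lower number, and compound 3 could still reach the limit. In this assay compound 3 is estimated at 1200 nM, with an expected range from 200 nM to 8000 nM.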

Compound 3, half-maximal inhibitory concentration: > 10000 nM
Compound 3: only a limit was reported; the forecaster's own chance of this, stated with the estimate: 25%; middle value at least 8.3-fold (0.92 log units) away from the limit.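

In this assay the result for compound 3 is a limit of the assay and not a number, and with compound 2 also at a limit, the step between the two dimethylbenzyl isomers cannot be read. The new information lies in the comparison with the 3-fluorophenyl group of compound 1, where 3,4-dimethylphenyl gives a large change beyond the scatter, an at least 94-fold higher number from compound 1 to compound 3 (1.97 log units; beyond the scatter), so the weak result on this saturated chain carbon is not confined to the 2,4-dimethylphenyl group. Keeping a substituent at the 3 position of the ring, as 3,4-dimethylphenyl does, therefore brings no readable recovery, and both dimethylphenyl isomers end at the same assay ceiling: the limit of > 10000 nM in this assay, at which 2 of the 3 values shown sit.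

Open, as far as these compounds go, is whether the gap to compound 1 follows the removal of fluorine or the presence of two methyl groups, a question that 3-methylphenyl or unsubstituted phenyl on the same chain carbon would address. Any order between compound 2 and compound 3 also remains unknown.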